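The compounds below may be only part of what the source reports. "The series", "measured", "known", "first", "only" and "open" are said of these compounds alone.

Measured so far in an assay on CHO cells for displacement of a labelled ligand from prostaglandin E2 receptor EP1 subtype (Homo sapiens); on this read-out higher numbers stand for weaker inhibition and lower numbers for stronger inhibition: compound 1 `CCOc1ccc(Cc2nnc(CN(c3cccc(Cl)c3C)S(=O)(=O)c3ccc(C)cc3)o2)cc1` gives 3.98 nM; compound 2 `Cc1ccc(S(=O)(=O)N(Cc2nnc(Cc3ccccc3Cl)o2)c2cccc(Cl)c2C)cc1` gives 79.4 nM.

For the measured compounds named here, compound 2 holds the highest number of the two, and the only measured step, a 20-fold higher number from compound 1 to compound 2 (1.30 log units; beyond the scatter), separates it from compound 1. Compound 3 `COc1ccc(Nc2nnc(CN(c3cccc(Cl)c3C)S(=O)(=O)c3ccc(C)cc3)o2)cc1` awaits measurement. The change from compound 2 to compound 3 is (4-methoxyphenyl)amino in place of 2-chlorobenzyl on an aromatic carbon. Going by the values given here, no measured step covers this exact change. The step of a 20-fold higher number from compound 1 to compound 2 (1.30 log units; beyond the scatter) bears on it only in part: it shows that exchanging the aryl group at this end of the core moves this assay by a large amount, and that the 4-ethoxyphenyl group of compound 1 went with the lower number. Compound 3 carries a 4-methoxyphenyl group, but joined through a nitrogen rather than a saturated chain carbon, so the likeness to compound 1 is partial. A step down in this assay is expected for compound 3, a 5.3-fold lower number from compound 2 to compound 3 (0.72 log units; beyond the scatter). Compound 3 is estimated at 15 nM, range 3 nM to 80 nM.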

Compound 3, half-maximal inhibitory concentration: 31.6 nM
The estimate for compound 3 lay 2.1-fold (0.32 log units) below the measured number; low and high end bracket the measured number.
By their numbers in this assay, from the lowest: compound 1; then compound 3; then compound 2.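

In this assay, (4-methoxyphenyl)amino in place of 2-chlorobenzyl gives a 2.5-fold lower number from compound 2 to compound 3 (0.40 log units; beyond the scatter), so at this aromatic carbon of the shared core a nitrogen-linked aryl group can give a lower number than the 2-chlorobenzyl group. Against 4-ethoxybenzyl the same exchange gives a 7.9-fold higher number from compound 1 to compound 3 (0.90 log units; beyond the scatter), so an alkoxy group at the 4-position of the aryl ring does not alone restore the lowest number in the set, though this exchange changes both the link and the alkoxy group at once. No measurement at hand accounts for either shift.

From the compounds shown here alone, it remains open whether the nitrogen link or the methoxy group accounts for the gap between the two alkoxy compounds, which a (4-ethoxyphenyl)amino group would separate. Also open, going by these compounds, is how this position responds to a non-aromatic group such as cyclohexyl.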